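Permeability notes on three measured analogues and one pending

The source may hold more compounds than are shown below. What is called first, only, known or untested is meant among the compounds shown, and "the series" means these compounds.

Measured in an ADME assay on Caco-2 cells (Homo sapiens) for permeability, read by LC-MS, with a stated time of 2 h; a higher number here means that the compound crosses the layer faster, a lower number that the compound crosses the layer more slowly:
compound 1, `CCCN(Cc1ccc(OCCN2C(=O)CCC2=O)c(C)c1)C(CC(=O)O)c1ccc(Cl)cc1`, gives 10.2 nm/s
compound 2, `CCCCN(Cc1ccc(OCCN2C(=O)CCC2=O)c(C)c1)C(CC(=O)O)c1ccc(Cl)cc1`, gives 13.5 nm/s
compound 3, `Cc1cc(CN(CC2CCCC2)[C@@H](CC(=O)O)c2ccc(Cl)cc2)ccc1OCCN1C(=O)CCC1=O`, gives 18.1 nm/s

Compound 4, `CCc1cc(CN(CC2CCCC2)[C@@H](CC(=O)O)c2ccc(Cl)cc2)ccc1OCCN1C(=O)CCC1=O`, has not been measured in this assay. It differs from compound 3 by methyl in place of hydrogen on a saturated chain carbon bound to an aromatic carbon. How the core of compound 3 differs from the core of compound 1 is not broken down here.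

The same kind of change, (methyl in place of hydrogen on a saturated chain carbon, three bonds along the chain from an amine nitrogen), links two measured compounds, and there it made a 1.3-fold higher number from compound 1 to compound 2 (0.12 log units; within the scatter). The surroundings of the two places are not identical: in the measured pair the carbon is three bonds along the chain from an amine nitrogen, whereas in the pending pair the carbon is bound to an aromatic carbon. The change is therefore the same kind of change, not the same one.

The values of compound 1, compound 2 and compound 3 lie close together, and no ordering among them is read from them.

For compound 4 in this assay the expected step is a 1.2-fold higher number from compound 3 to compound 4 (0.06 log units; within the scatter), set beside a 1.3-fold higher number from compound 1 to compound 2 (0.12 log units; within the scatter) because that measured step stayed within the usual scatter. On that basis compound 4 is estimated at 21 nm/s, with the range 12 nm/s to 36 nm/s; a single precedent is a thin basis, so the range is kept wide.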

Compound 4, apparent permeability: 57.3 nm/s
The estimate for compound 4 lay 2.7-fold (0.44 log units) below the measured number; the whole stated range lies below it.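

In this assay, methyl in place of hydrogen on a saturated chain carbon bound to an aromatic carbon, which reads as methyl to ethyl, gives a 3.2-fold higher number from compound 3 to compound 4 (0.50 log units; beyond the scatter). Set beside the earlier step, the same kind of change on the two cores gives steps that cannot be told apart: the same change on two cores in this assay, a 1.3-fold higher number (0.12 log units; within the scatter) from compound 1 to compound 2 and a 3.2-fold higher number (0.50 log units; beyond the scatter) from compound 3 to compound 4, 2.4-fold (0.38 log units) apart, within the scatter of two such steps. For the compounds shown here, this shows that one pair on the core of compound 3 gave a step beyond the scatter, but it does not show that the size of the step depends on the core, nor that it carries over unchanged from one core to the other, since there is only one pair per core and the changed carbon sits in a different place in each pair: three bonds along the chain from an amine nitrogen in one, bound to an aromatic carbon in the other.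

The compounds shown leave open whether a longer chain, such as propyl, in place of the ethyl of compound 4 would extend or reverse the step, and whether a polar group such as an amine at that place would read differently. They also leave open how the methyl to ethyl change reads on the core of compound 1, which would give a direct comparison at the same place.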